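Naphthyl to phenyl on the sulfonyl of the cinnamyl hydroxamate

The source may report more compounds than this note shows. Statements on the series, on what has been measured and on what is new or still open speak of the compounds shown alone.

Measured so far:
compound 1 `O=C(NO)c1cnc(N2CCN(S(=O)(=O)c3ccc4ccccc4c3)CC2)s1` — 2000 nM in a functional assay on MCF7 cells (Homo sapiens) for antiproliferative activity; on this read-out lower numbers stand for stronger inhibition of growth and higher numbers for weaker inhibition of growth
compound 2 `COc1ccc(S(=O)(=O)N2CCN(c3ncc(C(=O)NO)s3)CC2)cc1OC` — 2000 nM
compound 3 `O=C(/C=C/c1cnc(N2CCN(S(=O)(=O)c3ccc4ccccc4c3)CC2)s1)NO` — 700 nM

Compound 3 gives the lowest number of the three, separated from compound 1 by a 2.9-fold lower number from compound 1 to compound 3 (0.46 log units; beyond the scatter) and from compound 2 by the same margin, both beyond the scatter; it is thus the strongest grower inhibitor in this set. Among the measured compounds shown here, its only measured neighbour step is the chain extension from compound 1, which is not the change now considered.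

Compound 4 `O=C(/C=C/c1cnc(N2CCN(S(=O)(=O)c3ccccc3)CC2)s1)NO` differs from compound 3 by phenyl in place of naphthalen-2-yl on a sulfonyl sulfur. For the measured compounds named here, no measured step bears on this change directly. Going by the values given here, the only hint comes from compound 1 and compound 2, which carry different aryl groups on the same sulfonyl and give the same number, suggesting the aryl portion is not strongly read by this assay. A step of a 1.4-fold higher number from compound 3 to compound 4 (0.15 log units; within the scatter) is therefore expected, within or close to the scatter. Compound 4 is estimated at 1000 nM, in the range 400 nM to 3000 nM.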

Compound 4, concentration for 50% growth inhibition: 3000 nM
Compound 4: middle estimate off by 3.0-fold (0.48 log units), on the low side; the range from low to high includes it.
By their numbers in this assay, from the lowest: compound 3; then compounds 1, 2 and 4 (each within the scatter of the next).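

In this assay the aryl group on the sulfonyl sulfur does register on the 2-(hydroxycarbamoyl)ethenyl compounds: phenyl in place of naphthalen-2-yl gives a step beyond the scatter (a 4.3-fold higher number from compound 3 to compound 4 (0.63 log units; beyond the scatter)). The matching numbers of compound 1 with 2000 nM and compound 2 with 2000 nM therefore cannot be taken to show that this aryl group is unread across the series, since they come from hydroxycarbamoyl compounds only. Nothing measured here explains what the second aromatic ring of naphthalen-2-yl contributes.

Open, as far as these compounds go, is whether the dimethoxyphenyl group of compound 2 would sit with phenyl or with naphthalen-2-yl on the 2-(hydroxycarbamoyl)ethenyl compounds. Also open, from the compounds shown here alone, is what a biphenyl or a benzyl group on the sulfonyl sulfur would give.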